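This account rests on a few compounds, and the source may have more. Where it says the series, first, only, none or still open, it means among the compounds named here.

Compound 1 `FC(F)(F)c1ccc(CSc2nc(Nc3cccc(Cl)c3)c3ccccc3n2)cc1` has been tested in a functional assay on MGC-803 cells (Homo sapiens) for cytotoxicity, read by MTT assay, with a stated time of 72 h (on this read-out higher numbers stand for weaker inhibition and lower numbers for stronger inhibition), where compound 1 gives 14600 nM. Within the data shown here, the only other compound with a number so far is compound 2 `Fc1ccc(Nc2nc(SCc3ccc(C(F)(F)F)cc3)nc3ccccc23)cc1`, which in this assay gives 9620 nM. These two differ only in the aryl group carried on the nitrogen on the aromatic ring, and the change gave a 1.5-fold lower number from compound 1 to compound 2 (0.18 log units; within the scatter). So compound 1 is one of just two measured compounds, and its number sits within the scatter of the number for compound 2; neither can be set apart from the other.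

Compound 3 `COc1ccc(Nc2nc(SCc3ccc(C(F)(F)F)cc3)nc3ccccc23)cc1OC` is the next member of the set. It differs from compound 1 by 3,4-dimethoxyphenyl in place of 3-chlorophenyl on a nitrogen on an aromatic ring. Among the measured compounds shown here, the one measured step that bears on this, the swap of the same aryl group from compound 1 to compound 2, stayed within the scatter. On that basis, no step beyond the scatter is expected in this assay for compound 3; the estimated change is a 1.2-fold lower number from compound 1 to compound 3 (0.09 log units; within the scatter). Compound 3 is therefore expected to give about 12000 nM, with a likely range from 4000 nM to 36000 nM.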

Compound 3, half-maximal inhibitory concentration: 16300 nM
Beside the measured number, compound 3's estimate is 1.4-fold (0.13 log units) below it; low and high end bracket the measured number.
By their numbers in this assay, from the lowest: compounds 2, 1 and 3 (each within the scatter of the next).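

In this assay the swap of 3-chlorophenyl for 3,4-dimethoxyphenyl on the nitrogen gives a 1.1-fold higher number from compound 1 to compound 3 (0.05 log units; within the scatter) and the swap of 4-fluorophenyl for the same group gives a 1.7-fold higher number from compound 2 to compound 3 (0.23 log units; within the scatter) so neither step can be told apart from repeat-to-repeat noise. Among these compounds, the earlier pair compared only two halogen-bearing phenyl groups, whereas this step brings in a larger group, with 10 heavy atoms in place of 7 and 2 hydrogen-bond acceptors in place of 0, and the number still stays within the scatter of both other compounds. Among these three compounds, then, the position takes quite different substituted phenyl groups without a measurable change in this cytotoxicity read-out, and no measurement at hand offers an explanation for this flat picture.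

From the compounds shown here alone, all three compounds carry a substituted phenyl ring on this nitrogen, so it remains open whether a phenyl ring bearing a carboxylic acid or a dimethylamino group would move the number beyond the scatter. Going by these compounds, it is equally open what a plain alkyl chain in place of the phenyl ring would do, and whether any change at this position can shift the number at all.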